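The source may hold more compounds than are shown below. What is called first, only, known or untested is meant among the compounds shown, and "the series" means these compounds.

Compound 1 `O=C(/C=C/c1ccc2c(c1)B(O)OC2)c1ccco1` carries a five-membered ring on its carbonyl carbon; in a functional assay on HCT-116 cells (Homo sapiens) for cytotoxicity, read by MTT assay, with a stated time of 48 h (on this read-out lower numbers stand for stronger inhibition and higher numbers for weaker inhibition), compound 1 gives 24100 nM. Compound 2 `O=C(/C=C/c1ccc2c(c1)B(O)OC2)c1cccs1` keeps the whole shared core and swaps that ring for another five-membered ring; in this assay compound 2 gives 14200 nM. For the measured compounds named here, the only step so far, a 1.7-fold lower number from compound 1 to compound 2 (0.23 log units; within the scatter), is small, so the two numbers cannot be told apart; compound 2 is simply one of two measured compounds whose results overlap.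

Compound 3 `O=C(/C=C/c1ccc2c(c1)B(O)OC2)c1cccnc1` again changes only the ring on the carbonyl carbon: pyridin-3-yl in place of thiophen-2-yl on a carbonyl carbon. Going by the values given here, the one measured step that bears on it, a 1.7-fold lower number from compound 1 to compound 2 (0.23 log units; within the scatter), also exchanged one aromatic ring for another at this same position and stayed within the scatter. With a single comparable step, and that one flat, no shift beyond the scatter is expected for compound 3 in this assay; the estimated step is a 1.1-fold higher number from compound 2 to compound 3 (0.05 log units; within the scatter). Compound 3 is therefore expected to give about 16000 nM, with a likely range from 5000 nM to 50000 nM.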

Compound 3, half-maximal inhibitory concentration: 20500 nM
Beside the measured number, compound 3's estimate is 1.3-fold (0.11 log units) below it, within the range that was stated.
By their numbers in this assay, from the lowest: compounds 2, 3 and 1 (each within the scatter of the next).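

Until now, only five-membered rings had stood on the carbonyl carbon; pyridin-3-yl shows that a six-membered aromatic ring can take this place with no readable shift in this assay. Exchanging thiophen-2-yl for pyridin-3-yl gives a 1.4-fold higher number from compound 2 to compound 3 (0.16 log units; within the scatter) and exchanging furan-2-yl for it gives a 1.2-fold lower number from compound 1 to compound 3 (0.07 log units; within the scatter), so neither exchange can be told apart from repeat-to-repeat variation. Across these three compounds, both the ring size and the hetero atom (sulfur, oxygen or nitrogen) differ, yet all three numbers remain within the scatter of one another, and no measurement on hand offers an explanation for this flat result.

Still open, going by these compounds, is whether a group of another kind on the carbonyl carbon would move the number beyond the scatter, such as a plain phenyl ring, a pyridine ring carrying an amine or a carboxylic acid, or a longer chain in place of the ring. The shared core is the same in all three compounds, so these results also cannot show whether a change within the core would matter more than a change at this position.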